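The source may hold more compounds than are shown below. What is called first, only, known or untested is meant among the compounds shown, and "the series" means these compounds.

Measured so far in a functional assay on HeLa cells (Homo sapiens) for antiproliferative activity, read by MTT assay, with a stated time of 48 h; a higher number here means a weaker inhibitor, a lower number a stronger inhibitor:
- compound 1 `COc1cccc(-c2nn(-c3ccccc3)cc2C(Nc2nc3ccccc3s2)c2c(O)ccc3ccccc23)c1`: 14900 nM
- compound 2 `COc1cccc(-c2nn(-c3ccccc3)cc2C(Nc2nc3ccc(OC)cc3s2)c2c(O)ccc3ccccc23)c1`: 10500 nM
- compound 3 `COc1cccc(-c2nn(-c3ccccc3)cc2C(Nc2nc3ccc(Cl)cc3s2)c2c(O)ccc3ccccc23)c1`: 30000 nM

Compound 3 is separated from only one of the other two compounds: the data show a 2.0-fold higher number from compound 1 to compound 3 (0.30 log units; within the scatter), and a 2.9-fold higher number from compound 2 to compound 3 (0.46 log units; beyond the scatter).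

Compound 4 `Oc1ccc2ccccc2c1C(Nc1nc2ccc(Cl)cc2s1)c1cn(-c2ccccc2)nc1-c1ccc(I)cc1` keeps the chloro group of compound 3 and carries 4-iodophenyl in place of 3-methoxyphenyl on an aromatic carbon of a five-membered aromatic ring with 2 nitrogen (4-iodophenyl in place of 3-methoxyphenyl on an aromatic carbon).

Among the measured compounds shown here, no measured step changes this position, so the evidence is indirect. The measured steps all involve substituents elsewhere in the molecule: a 1.4-fold lower number from compound 1 to compound 2 (0.15 log units; within the scatter), a 2.0-fold higher number from compound 1 to compound 3 (0.30 log units; within the scatter) and a 2.9-fold higher number from compound 2 to compound 3 (0.46 log units; beyond the scatter). The last of these is the only one beyond the scatter, and it is modest. For the measured compounds named here, with no direct precedent, no firm direction can be assigned, and no shift beyond the scatter is expected. The expected change is a 1.5-fold lower number from compound 3 to compound 4 (0.18 log units; within the scatter). The estimated value for compound 4 is 20000 nM, with an expected range of 6000 nM to 60000 nM.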

Compound 4, half-maximal inhibitory concentration: 12100 nM
Compound 4: middle estimate off by 1.7-fold (0.22 log units), on the high side; the measured number falls inside the stated range.
By their numbers in this assay, from the lowest: compounds 2, 4, 1 and 3 (each within the scatter of the next, the first and the last beyond it).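

In this assay, among the compounds shown here, the first change at this position moves the number beyond the scatter: 4-iodophenyl in place of 3-methoxyphenyl gives a 2.5-fold lower number from compound 3 to compound 4 (0.39 log units; beyond the scatter). The chloro group stays the same across this step, so the aryl group on the five-membered aromatic ring with 2 nitrogen is a second place in the molecule where the read-out shifts modestly, alongside the chloro-for-methoxy exchange on the other side of the molecule. No measurement shown here accounts for the shift.

Going by these compounds, this single step swaps the substituent and its place on the phenyl ring together, so the contribution of each stays open; 3-iodophenyl or 4-methoxyphenyl would separate the two. On these data alone, how an aminophenyl or carboxyphenyl group would read at this position in this assay also remains open.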